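This account rests on a few compounds, and the source may have more. Where it says the series, first, only, none or still open, it means among the compounds named here.

Three compounds share one core and differ in a single group on a six-membered aromatic ring of carbon only. Compound 1 `N#Cc1c(-c2ccccc2)c(C#N)c(=O)n(/N=C/c2cn(-c3ccccc3)nc2-c2ccccc2)c1N` carries hydrogen at that place, compound 2 `N#Cc1c(-c2ccc(F)cc2)c(C#N)c(=O)n(/N=C/c2cn(-c3ccccc3)nc2-c2ccccc2)c1N` carries fluoro and compound 3 `N#Cc1c(-c2ccc([N+](=O)[O-])cc2)c(C#N)c(=O)n(/N=C/c2cn(-c3ccccc3)nc2-c2ccccc2)c1N` carries nitro. In an ADME assay on HeLa cells (Homo sapiens) for cytotoxicity, read by MTT assay (on this read-out lower numbers stand for stronger inhibition and higher numbers for weaker inhibition), compound 1 gives > 200 ug/mL, which is a limit of the assay and not a number. In this assay compound 2 likewise reaches only a limit, > 200 ug/mL. Compound 3 also stands at a limit in this assay, > 200 ug/mL. Because of the limit of > 200 ug/mL in this assay, at which 3 of the 3 values shown sit, none of the steps among them can be read: a step that the two limits leave unreadable from compound 1 to compound 2, a step that the two limits leave unreadable from compound 1 to compound 3 and a step that the two limits leave unreadable from compound 2 to compound 3 all remain unreadable in size and direction.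

Compound 4 `N#Cc1c(-c2ccc(C(F)(F)F)cc2)c(C#N)c(=O)n(/N=C/c2cn(-c3ccccc3)nc2-c2ccccc2)c1N` has not yet been measured. It differs from compound 2 in one place (trifluoromethyl in place of fluoro on an aromatic carbon). The three measured steps bear on this change only in that each of them left the read-out at the limit, so no step beyond the scatter is expected here either. The step of a number no higher from compound 2 to compound 4 (the limit leaves the size open) is therefore expected to be none beyond the scatter. Compound 4 is estimated in this assay at 200 ug/mL, with a range from 100 ug/mL to 400 ug/mL.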

Compound 4, half-maximal inhibitory concentration: > 200 ug/mL
Compound 4 was reported as a limit; the forecaster's own chance of this, stated with the estimate: 80%; the middle value sits exactly at the limit.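

Compound 4 also reaches only a limit in this assay, > 200 ug/mL. No step between compound 4 and compound 1, compound 2 or compound 3 can be read, because all four compounds sit at the same limit: the limit of > 200 ug/mL in this assay, at which 4 of the 4 values shown sit.

The compounds shown leave open whether hydrogen, fluoro, nitro and trifluoromethyl differ at all in this assay.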